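Compound 3: new group on the aromatic nitrogen of compound 2

The compounds below may be only part of what the source reports. "The series", "measured", "known", "first", "only" and "open" are said of these compounds alone.

Measured so far:
compound 1 `CC(C)(C)OC(=O)N[C@@H](Cn1cc(CN2CCN(c3cccc4[nH]c(-c5ccc(C(C)(C)C)cc5)nc34)CC2)nn1)C(=O)O` — 10000 nM
compound 2 `CC(C)(C)c1ccc(-c2nc3c(N4CCN(Cc5cn([C@@H]6O[C@H](CO)[C@@H](O)[C@H](O)[C@H]6O)nn5)CC4)cccc3[nH]2)cc1` — > 10000 nM

In a functional assay on cells for antagonist activity at Gonadotropin-releasing hormone receptor (Homo sapiens), read by FLIPR and calcium flux, with a stated time of 15 min (a higher number here means a weaker inhibitor, a lower number a stronger inhibitor), compound 1 gives 10000 nM. Compound 2 sits at the limit of > 10000 nM in this assay, at which 1 of the 2 values shown sits, so for compound 2 only a limit of this assay is known, not a number. Among the measured compounds shown here, no step between compound 1 and compound 2 is measured; both stand at the weak end of what this assay resolves.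

Compound 3 `CC(C)(C)c1ccc(-c2nc3c(N4CCN(Cc5cn(-c6nc7ccccc7[nH]6)nn5)CC4)cccc3[nH]2)cc1` has not yet been measured. It differs from compound 2 in one place: 1H-benzimidazol-2-yl in place of 3,4,5-trihydroxy-6-(hydroxymethyl)oxan-2-yl on an aromatic nitrogen. For the measured compounds named here, no measured step covers this change, so any expectation rests on the two values alone. With compound 2 at a limit, a step toward weaker inhibition in this assay would not be visible, while a step toward stronger inhibition could be of any size. Compound 3 is expected near 3000 nM, with a range of 500 nM to 10000 nM. The step expected is an at least 3.3-fold lower number from compound 2 to compound 3 (0.52 log units; beyond the scatter), toward stronger inhibition but with wide uncertainty.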

Compound 3, half-maximal inhibitory concentration: 5010 nM
The estimate for compound 3 lay 1.7-fold (0.22 log units) below the measured number, within the range that was stated.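

Among the compounds shown here, replacing 3,4,5-trihydroxy-6-(hydroxymethyl)oxan-2-yl with 1H-benzimidazol-2-yl on this aromatic nitrogen gives an at least 1.9-fold lower number from compound 2 to compound 3 (0.30 log units; that floor lies within the scatter), the first step that can be read at this position in this assay. The size of that step is only a floor, and compound 2 carries a limit rather than a number: the limit of > 10000 nM in this assay, at which 1 of the 3 values shown sits. The position therefore accepts a group of two aromatic rings in place of the non-aromatic ring with its 5 defined stereocentres, with no readable loss.

As far as these compounds go, it remains open whether a plain phenyl ring or a methyl group on this nitrogen would move the number further. From the compounds shown here alone, it also remains open whether a benzimidazole bearing an amine or a carboxylic acid on a longer chain would shift it in either direction.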